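Notes on the aryl amide change, compound 2 to compound 3

The compounds below may be only part of what the source reports. "The series", "measured", "known", "first", "only" and "open" are said of these compounds alone.

Compound 1 `COc1ccc(C(=O)Nc2cccc(-c3oc4cc(-c5ccc(F)cc5)ccc4c(=O)c3O)c2)cc1` gives 8700 nM in a functional assay on A549 cells (Homo sapiens) for antiproliferative activity, read by CCK-8 assay, with a stated time of 72 h; on this read-out higher numbers stand for weaker inhibition and lower numbers for stronger inhibition. Among the measured compounds shown here, compound 2 `O=C(Nc1cccc(-c2oc3cc(-c4ccc(F)cc4)ccc3c(=O)c2O)c1)c1ccc(Br)cc1F` gives 46100 nM in this assay, the higher of the two numbers so far, with compound 1 the nearest. For the measured compounds named here, the single step known, a 5.3-fold higher number from compound 1 to compound 2 (0.72 log units; beyond the scatter), came from a change on the carbonyl carbon of the amide. Compound 3 `O=C(Nc1cccc(-c2oc3cc(-c4ccc(F)cc4)ccc3c(=O)c2O)c1)c1ccc([N+](=O)[O-])cc1` differs from compound 2 by 4-nitrophenyl in place of 4-bromo-2-fluorophenyl on a carbonyl carbon. Going by the values given here, since the only step that bears on this, a 5.3-fold higher number from compound 1 to compound 2 (0.72 log units; beyond the scatter), was modest, a step of similar or smaller size is expected here, most likely toward a lower number, a 1.8-fold lower number from compound 2 to compound 3 (0.27 log units; within the scatter). Compound 3 is estimated at 25000 nM, within 7000 nM to 80000 nM.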

Compound 3, half-maximal inhibitory concentration: 2440 nM
For compound 3 the middle estimate is 10-fold (1.01 log units) above the measured one; the whole stated range lies above it.
By their numbers in this assay, from the lowest: compound 3; then compound 1; then compound 2.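

In this assay, among the compounds shown here, the aryl group on the amide carbonyl proves able to move the number in both directions: 4-nitrophenyl in place of 4-bromo-2-fluorophenyl gives the largest step so far (a 19-fold lower number from compound 2 to compound 3 (1.28 log units; beyond the scatter)), and nitro in place of methoxy on an aromatic carbon also lowers the number (a 3.6-fold lower number from compound 1 to compound 3 (0.55 log units; beyond the scatter)). No measurement on hand accounts for either step. Still open, as far as these compounds go, is whether an amine or a carboxylic acid on that aromatic carbon would track compound 3, and whether the bromine or the fluorine of compound 2 sets its high number.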